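Imidazole for aminothiazole at the chain end of compound 1

The compounds below may be only part of what the source reports. "The series", "measured", "known", "first", "only" and "open" are said of these compounds alone.

Compound 1 `Cc1nc(N)sc1CCCNC(=N)NC(=O)C[C@@H](C)c1ccccc1` gives 17 nM in an in vitro functional assay on Sf9 cells for agonist activity at histamine H2 receptor (Cavia porcellus), read by GTPgammaS binding; a higher number here means that more compound is needed for the effect, a lower number that less compound is needed. Compound 2 `Cc1nc(N)sc1CCCNC(=N)NC(=O)C[C@H](C)C1CCCCC1` gives 14.1 nM in this assay, and the step of a 1.2-fold lower number from compound 1 to compound 2 (0.08 log units; within the scatter) leaves the two numbers within the scatter of each other. Compound 3 `C[C@H](CC(=O)NC(=N)NCCCc1c[nH]cn1)c1ccccc1` has not been measured yet. It differs from compound 1 by 1H-imidazol-4-yl in place of 2-amino-4-methyl-1,3-thiazol-5-yl on a saturated chain carbon, three bonds along the chain from an amine nitrogen. Within the data shown here, no measured step bears on this exchange: the only step, a 1.2-fold lower number from compound 1 to compound 2 (0.08 log units; within the scatter), alters the group on the carbon bound to the carbonyl and keeps the aminothiazole, so it gives no guidance on the imidazole. With nothing in the two numbers pointing either way, the expected step of a 2.1-fold higher number from compound 1 to compound 3 (0.31 log units; beyond the scatter) is set as a modest move toward a higher number, with a wide range to reflect the missing information. Compound 3 is thus estimated at 35 nM in this assay, with a range from 8 nM to 150 nM.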

Compound 3, half-maximal effective concentration: 75.9 nM
Estimate against measurement, compound 3: 2.2-fold (0.34 log units) below; the measured number falls inside the stated range.
By their numbers in this assay, from the lowest: compounds 2 and 1 (each within the scatter of the next); then compound 3.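

In this assay, 1H-imidazol-4-yl in place of 2-amino-4-methyl-1,3-thiazol-5-yl gives a 4.5-fold higher number from compound 1 to compound 3 (0.65 log units; beyond the scatter) and so exceeds the scatter. This position therefore responds to the choice of ring, whereas the other exchange in the series, 1-cyclohexylethyl for 1-phenylethyl, gives a 1.2-fold lower number from compound 1 to compound 2 (0.08 log units; within the scatter) and stays within it. No measurement on hand accounts for the difference between the two rings.

From the compounds shown here alone, whether the exchange of rings gives a step of similar size with 1-cyclohexylethyl in place of 1-phenylethyl remains open. Also open, going by these compounds, is which part of the 2-amino-4-methyl-1,3-thiazol-5-yl group matters, a question that a 2-amino-1,3-thiazol-5-yl group without the methyl or a 4-methyl-1H-imidazol-5-yl group could help to separate.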